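Sulfonamide series on a fused bicyclic core: antiproliferative readout

A few compounds are considered here, and "the series" means these few. Any claim that something is new, unique, unknown or untested is made for them only; others in the source may bear on it.

Measured compounds:
- compound 1, `Cc1ccc(S(=O)(=O)Nc2ccc(-c3cccnc3)c3cccnc23)cc1`: 7130 nM
- compound 2, `O=S(=O)(Nc1ccc(-c2cccnc2)c2cccnc12)c1cccc(C(F)(F)F)c1`: 5910 nM
- compound 3, `O=S(=O)(Nc1ccc(-c2cccnc2)c2cccnc12)c1cccnc1`: 1490 nM

All three share a core and differ only in the aryl group on the sulfonyl sulfur. In a functional assay on A549 cells (Homo sapiens) for antiproliferative activity, with a stated time of 2 days (a higher number here means a weaker inhibitor, a lower number a stronger inhibitor), compound 3 gives the lowest of the three numbers: the step of a 4.8-fold lower number from compound 1 to compound 3 (0.68 log units; beyond the scatter) and the step of a 4.0-fold lower number from compound 2 to compound 3 (0.60 log units; beyond the scatter) both lie beyond the scatter, whereas a 1.2-fold lower number from compound 1 to compound 2 (0.08 log units; within the scatter) does not. Compound 3 is therefore the strongest inhibitor among the measured compounds in this assay.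

Compound 4, `O=S(=O)(Nc1ccc(-c2ccncc2)c2cccnc12)c1cccnc1`, keeps the pyridin-3-yl sulfonamide of compound 3 and moves the ring nitrogen of the other group: pyridin-4-yl in place of pyridin-3-yl on an aromatic carbon. Among the measured compounds shown here, none of the measured steps touches this position; every one of them alters the sulfonyl aryl group instead, so there is no direct precedent for how this assay responds to the change. The rearrangement is small, with the same atoms joined differently, and the default expectation is a step of no more than the usual scatter in either direction. The estimated step is a 1.1-fold higher number from compound 3 to compound 4 (0.03 log units; within the scatter), i.e. compound 4 is expected to stay close to compound 3. The estimate for compound 4 in this assay is 1600 nM, with a range from 600 nM to 4500 nM.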

Compound 4, half-maximal inhibitory concentration: 11800 nM
Estimate against measurement, compound 4: 7.4-fold (0.87 log units) below; measured number outside the range, above it.
By their numbers in this assay, from the lowest: compound 3; then compounds 2, 1 and 4 (each within the scatter of the next).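

Position note: the pyridine on the aromatic carbon para to a large group is not a neutral spot in this assay, since pyridin-4-yl in place of pyridin-3-yl gives a 7.9-fold higher number from compound 3 to compound 4 (0.90 log units; beyond the scatter) and so moves the number beyond the scatter with the same atoms, joined differently. The earlier compounds shown here all carried pyridin-3-yl here and varied only the aryl group on the sulfonyl sulfur, so they gave no reading of this site; it now appears that relocating the ring nitrogen alone, with the counted heavy atoms, donors and acceptors unchanged, is enough to shift the readout. No measured evidence bears on the origin of this step, so the result stands as an observation only.

Among the compounds shown here, open: whether the same change gives a step of similar size with 4-methylphenyl or 3-(trifluoromethyl)phenyl on the sulfonyl sulfur, since the only pair read here carries pyridin-3-yl there. Also open, as far as these compounds go, is how pyridin-2-yl, a plain phenyl or a morpholine ring would read on this aromatic carbon.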